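The source may hold more compounds than are shown below. What is called first, only, known or untested is meant among the compounds shown, and "the series" means these compounds.

Three pyrazolines sharing one core have been measured, and a fourth awaits its result. Compound 1 `c1ccc(COc2cccc(C3CC(c4ccc5c(c4)OCCO5)=NN3c3ccccc3)c2)cc1` gives 870 nM in a functional assay on WM 266-4 cells (Homo sapiens) for antiproliferative activity, read by MTT assay, with a stated time of 24 h (a higher number here means a weaker inhibitor of growth, a lower number a stronger inhibitor of growth), the lowest of the three numbers. Compound 3 `Brc1ccc(C2CC(c3ccc4c(c3)OCCO4)=NN2c2ccccc2)cc1` gives 3010 nM in this assay, and compound 2 `c1ccc(N2N=C(c3ccc4c(c3)OCCO4)CC2c2ccc3ccccc3c2)cc1` gives 13900 nM in this assay, so compound 1 stands apart from both by a margin beyond the scatter, with compound 3 nearer and compound 2 furthest.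

The unmeasured compound 4 `c1ccc(C2CC(c3ccc4c(c3)OCCO4)=NN2c2ccccc2)cc1` is derived from compound 1 by a single change: hydrogen in place of benzyloxy on an aromatic carbon. Among the measured compounds shown here, the only measured step that touches the same part of the molecule, the aryl group on the saturated ring carbon, is a 4.6-fold lower number from compound 2 to compound 3 (0.66 log units; beyond the scatter), where a smaller group brought a lower number. That step concerns a different pair of groups, so it offers only indirect guidance. Removing the benzyloxy leaves a plain phenyl, closer in size to the aryl of compound 3 than to that of compound 1, and compound 3 gives 3010 nM in this assay.

On that basis compound 4 is expected to give a higher number than compound 1, a step of a 4.6-fold higher number from compound 1 to compound 4 (0.66 log units; beyond the scatter), with an estimate of 4000 nM and a range from 1500 nM to 12000 nM.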

Compound 4, concentration for 50% growth inhibition: 22400 nM
Compound 4: middle estimate off by 5.6-fold (0.75 log units), on the low side; measured number outside the range, above it.
By their numbers in this assay, from the lowest: compound 1; then compound 3; then compounds 2 and 4 (each within the scatter of the next).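

In this assay, among the compounds shown here, the benzyloxy group on the aromatic carbon meta to a large group proves to matter far more than the earlier compounds could show: hydrogen in its place gives a 26-fold higher number from compound 1 to compound 4 (1.41 log units; beyond the scatter) and is a large step. Hydrogen in place of bromo points the same way, with a 7.4-fold higher number from compound 3 to compound 4 (0.87 log units; beyond the scatter) on that pair, so both compounds with a substituted phenyl, compound 1 and compound 3, stand below the plain phenyl of compound 4, while phenyl in place of naphthalen-2-yl gives a 1.6-fold higher number from compound 2 to compound 4 (0.21 log units; within the scatter) and so does not extend the earlier trend of a smaller aryl group bringing a lower number. Nothing in the material shown accounts for these differences.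

The compounds shown leave open whether the low number of compound 1 depends on the oxygen link or on the added aromatic ring of benzyloxy, and whether methoxy, phenoxy or an amine on that same carbon would hold the number down. They also leave open whether benzyloxy would act alike on another carbon of that ring.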